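Removing the para fluorine from a thiosemicarbazone

This account rests on a few compounds, and the source may have more. Where it says the series, first, only, none or still open, it means among the compounds named here.

Measured so far:
- compound 1, `C/C(=N/NC(=S)Nc1ccccc1F)c1ccccn1`: 0.39 nM
- compound 2, `CC(=NNC(=S)Nc1ccccc1)c1ccccn1`: 0.18 nM
- compound 3, `C/C(=N/NC(=S)Nc1ccc(F)cc1)c1ccccn1`: 1.2 nM

These three compounds were tested in a functional assay on MCF7 cells (Homo sapiens) for cytotoxicity, read by MTT assay, with a stated time of 48 h; a higher number here means a weaker inhibitor, a lower number a stronger inhibitor. Compound 3 stands highest of the three numbers; compound 1 is nearest, with a lower number that lies beyond the scatter, and compound 2 is furthest, with a still lower number, also beyond the scatter. Compound 3 is therefore the weakest of the three in this assay.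

Compound 4, `C/C(=N/NC(=S)Nc1ccccc1)c1ccccn1`, has not yet been measured. It differs from compound 3 in one place: hydrogen in place of fluoro on an aromatic carbon. Among the compounds with values here, no step between two measured compounds corresponds to this change, so the direction has to be taken from what the three values show. Compound 2 gives 0.18 nM in this assay, and its structure carries hydrogen at the same position, which points toward a lower number for compound 4 than for compound 3. The expected step of a 4.0-fold lower number from compound 3 to compound 4 (0.60 log units; beyond the scatter) is therefore downward and beyond the scatter, though its size is uncertain. Compound 4 is estimated at 0.3 nM, with a range from 0.1 nM to 0.9 nM.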

Compound 4, half-maximal inhibitory concentration: 0.18 nM
For compound 4 the middle estimate is 1.7-fold (0.22 log units) above the measured one; low and high end bracket the measured number.
By their numbers in this assay, from the lowest: compounds 2 and 4 (each within the scatter of the next); then compound 1; then compound 3.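

In this assay, the place para to a large group now has a measured step of its own, a 6.7-fold lower number from compound 3 to compound 4 (0.82 log units; beyond the scatter), for hydrogen in place of fluoro on an aromatic carbon. The same exchange at the other fluoro-bearing place on the ring gives a 2.2-fold lower number from compound 1 to compound 4 (0.34 log units; beyond the scatter), so among these compounds fluoro at either place goes with a higher number than hydrogen does, and none of them goes against this. The remaining step, no change at the digits printed from compound 2 to compound 4 (within the scatter), says nothing about the configuration of the double bond, and one fact limits what it can show: the fact that one of compounds 2 and 4 is drawn with a defined configuration and the other without, at the place where they differ

As far as these compounds go, whether a chlorine, a methoxy group or an amine at the place para to a large group would give a number nearer to that of hydrogen or to that of fluoro remains open. Also open, from the compounds shown here alone, are how a double bond with the opposite configuration would compare with compound 4, and whether the exchange of fluoro for hydrogen would run the same way in cells other than those of this assay.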